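The source may report more compounds than this note shows. Statements on the series, on what has been measured and on what is new or still open speak of the compounds shown alone.

Among the measured compounds shown here, in an ADME assay on Vero cells (Chlorocebus sabaeus) for cytotoxicity, read by resazurin assay, with a stated time of 72 h (on this read-out lower numbers stand for stronger inhibition and higher numbers for weaker inhibition), three compounds have numbers so far. Compound 1 (`Cc1ccc(C(=O)CCN2CCN(c3ccc([N+](=O)[O-])cc3)CC2)cc1`) gives 235000 nM, compound 2 (`COc1ccc(C(=O)CCN2CCN(c3ccc(F)cc3)CC2)cc1`) gives 55000 nM and compound 3 (`COc1ccc(C(=O)CCN2CCN(c3ccc(C(F)(F)F)cc3)CC2)cc1`) gives 135000 nM. Compound 3 stands within the scatter of compound 1, while compound 2 lies beyond the scatter on the lower side of compound 3.

Next is compound 4 (`COc1ccc(C(=O)CCN2CCN(c3ccc([N+](=O)[O-])cc3)CC2)cc1`), still unmeasured in this assay. The change from compound 3 is nitro in place of trifluoromethyl on an aromatic carbon, para to a large group.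

For the measured compounds named here, one measured step bears directly on this place: a 2.5-fold higher number from compound 2 to compound 3 (0.39 log units; beyond the scatter), a modest change with trifluoromethyl in place of fluoro. Going by the values given here, no measured step exchanges trifluoromethyl for nitro. Among the compounds with values here, the only measured nitro compound is compound 1 at 235000 nM, and it carries methyl where compound 4 carries methoxy. Its number sits within the scatter of compound 3, so no step beyond the scatter is expected in this assay, and any direction would be weakly founded, with a slight lean towards higher numbers. The expected size is a 1.2-fold higher number from compound 3 to compound 4 (0.07 log units; within the scatter). The estimate for compound 4 is 160000 nM, with an expected range from 75000 nM to 320000 nM.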

Compound 4, half-maximal inhibitory concentration: 587000 nM
The estimate for compound 4 lay 3.7-fold (0.56 log units) below the measured number; measured number outside the range, above it.
By their numbers in this assay, from the lowest: compound 2; then compounds 3 and 1 (each within the scatter of the next); then compound 4.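

Within this assay, nitro in place of trifluoromethyl on an aromatic carbon, para to a large group, gives a 4.3-fold higher number from compound 3 to compound 4 (0.64 log units; beyond the scatter) and so separates two groups that the earlier values did not set apart. With nitro in place of fluoro giving an 11-fold higher number from compound 2 to compound 4 (1.03 log units; beyond the scatter) as the largest step here, the three compounds with methoxy at the other end now rise in the order fluoro, trifluoromethyl, nitro, each beyond the scatter of the next. Among the compounds shown here, the other end of the series also matters, as methoxy in place of methyl on an aromatic carbon, with nitro held constant, gives a 2.5-fold higher number from compound 1 to compound 4 (0.40 log units; beyond the scatter) and provides the first measured step at that place, though nothing measured here gives a reason for any of these steps.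

From the compounds shown here alone, whether methoxy in place of methyl produces a step of similar size and direction with fluoro or trifluoromethyl in the other position remains open, as only the nitro pair can be read. Going by these compounds, it is also open where a nitrile, a carboxylic acid or an amine at the position para to a large group would fall relative to the order of fluoro, trifluoromethyl and nitro.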